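Sulfonylacetate esters: isopropyl added on the aniline ring

The source may report more compounds than this note shows. Statements on the series, on what has been measured and on what is new or still open speak of the compounds shown alone.

Compound 1 `CC(C)c1cccc(C(C)C)c1NS(=O)(=O)CC(=O)Oc1c(C(C)C)cccc1C(C)C`: in an assay on microsomes from intestine for inhibition of acyl-CoA:cholesterol acyltransferase (Oryctolagus cuniculus) (a higher number here means a weaker inhibitor, a lower number a stronger inhibitor), compound 1 gives > 1000 nM, which is a limit of the assay and not a number.
Compound 2 `CCCCCCCCCCCCC(C)OC(=O)CS(=O)(=O)Nc1c(C(C)C)cccc1C(C)C`: compound 2 gives 21 nM.
Compound 3 `CC(C)c1cc(C(C)C)c(OC(=O)CS(=O)(=O)Nc2c(C(C)C)cccc2C(C)C)c(C(C)C)c1`: compound 3 gives 2800 nM.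

Compound 1 stands only at the limit (the limit of > 1000 nM in this assay, at which 1 of the 3 values shown sits), so its place among the numbers shown cannot be fixed. Of the two compounds with numbers, compound 2 gives 21 nM while compound 3 gives 2800 nM, and these two values lie well apart.

Compound 4 `CC(C)c1cc(C(C)C)c(NS(=O)(=O)CC(=O)Oc2c(C(C)C)cccc2C(C)C)c(C(C)C)c1` has not been measured. It differs from compound 1 by isopropyl in place of hydrogen on an aromatic carbon. For the measured compounds named here, the one measured step of the same kind is a step that the limit leaves unreadable from compound 1 to compound 3, where the isopropyl was added on the ester-side ring instead; because compound 1 sits at the limit (the limit of > 1000 nM in this assay, at which 1 of the 3 values shown sits), the size of that step cannot be read. Compound 3, carrying such an added isopropyl, gives 2800 nM, and nothing among the shown values suggests that adding the same group on the aniline-side ring should move the result into the range of compound 2. The step from compound 1 to compound 4 is therefore expected to be small or unreadable: a step that the limit leaves unreadable from compound 1 to compound 4. Compound 4 is estimated at 3000 nM, with a range from 1000 nM to 10000 nM.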

Compound 4, half-maximal inhibitory concentration: > 1000 nM
Compound 4 gave a limit, no number (the forecaster's own chance of this, stated with the estimate: 40%); the middle value is on the limit's open side.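

In this assay compound 4 gives > 1000 nM, which is a limit of the assay and not a number. Compound 1 also stands at a limit, so no step between compound 1 and compound 4 can be read: the limit of > 1000 nM in this assay, at which 2 of the 4 values shown sit.

The compounds shown leave open how far isopropyl in place of hydrogen on an aromatic carbon moves the result from compound 1, in either compound 3 or compound 4.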